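The source may report more compounds than this note shows. Statements on the series, on what has been measured and on what is new or still open speak of the compounds shown alone.

Three compounds built on one shared core were tested in a functional assay on MCF7 cells (Homo sapiens) for antiproliferative activity, read by CCK-8 assay, with a stated time of 72 h; a lower number here means a stronger inhibitor of growth, a higher number a weaker inhibitor of growth. Compound 1 `CC[C@@H]1C(=O)N(C)c2cnc(Nc3ccc(S(N)(=O)=O)cc3)nc2N1C1CCCC1` gives 394 nM in this assay. Compound 2 `CCCCNS(=O)(=O)c1ccc(Nc2ncc3c(n2)N(c2ccn(C)n2)C(CC)C(=O)N3C)cc1` gives 5780 nM, and compound 3 `CC[C@@H]1C(=O)N(C)c2cnc(-n3ccc4cc(C(=O)NC(C)C)ccc43)nc2N1C1CCCC1` gives 1670 nM. Compound 3 therefore stands second highest of the three numbers, closer to compound 2 than to compound 1. Compound 4 `CCCNC(=O)c1ccc2c(ccn2-c2ncc3c(n2)N(C2CCCC2)[C@H](CC)C(=O)N3C)c1` has not yet been measured. It differs from compound 3 in a single place: propyl in place of isopropyl on an amide-type nitrogen. For the measured compounds named here, no measured pair differs by exactly this swap, so nothing in the numbers shows how it has shifted growth inhibition before. Since the change only rearranges a short chain, the step is expected to be small and within the usual scatter: a 1.1-fold lower number from compound 3 to compound 4 (0.05 log units; within the scatter). Compound 4 is thus estimated at about 1500 nM, between 600 nM and 4000 nM.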

Compound 4, concentration for 50% growth inhibition: 592 nM
Beside the measured number, compound 4's estimate is 2.5-fold (0.40 log units) above it, outside the stated range (below it).
By their numbers in this assay, from the lowest: compounds 1 and 4 (each within the scatter of the next); then compound 3; then compound 2.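

Joining the same three carbons as a straight propyl rather than a branched isopropyl on the amide-type nitrogen gives a 2.8-fold lower number from compound 3 to compound 4 (0.45 log units; beyond the scatter). For the compounds shown here, this shows that growth inhibition at this position depends on how the chain is joined, not only on its atom count, something no earlier pair could reveal. Nothing shown accounts for the size of this step. From the compounds shown here alone, whether a longer chain such as pentyl, or an amine at the end of the propyl, would lower the number further remains open.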